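Chloro for fluoro in a hydroxyamino pyranone amide series

The source may report more compounds than this note shows. Statements on the series, on what has been measured and on what is new or still open speak of the compounds shown alone.

The study follows a set of pyranone amides through an ADME assay on Huh-7 cells (Homo sapiens) for cytotoxicity, read by a luciferase reporter and WST assay, with a stated time of 3 days; on this read-out higher numbers stand for lower toxicity in this test and lower numbers for higher toxicity in this test. Compound 1 `O=C(Nc1ccc(F)cc1)c1c(NO)cc(-c2ccccc2)oc1=O` reaches only the limit of this assay, with > 20000 nM. Compound 2 `O=C(Nc1ccc(Cl)cc1)c1c(NO)cc(-c2ccccc2)oc1=O` likewise stops at the limit, at > 20000 nM. Compound 3 `Cc1ccc(NC(=O)c2c(NO)cc(-c3ccc(F)cc3)oc2=O)cc1` also sits at the limit, with > 20000 nM. The change from compound 1 to compound 2 is chloro in place of fluoro on an aromatic carbon, and a step that the two limits leave unreadable from compound 1 to compound 2 cannot be read. The difference between the core of compound 1 and that of compound 3 is not broken down here. Compound 4 `Cc1ccc(NC(=O)c2c(NO)cc(-c3ccc(Cl)cc3)oc2=O)cc1` carries the same change, (chloro in place of fluoro on an aromatic carbon). Among the measured compounds shown here, since the limit of > 20000 nM in this assay, at which 3 of the 3 values shown sit, holds every value measured so far, the step that the limit leaves unreadable from compound 3 to compound 4 is expected to be small or unreadable. Compound 4 is estimated at 30000 nM in this assay, between 20000 nM and 100000 nM.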

Compound 4, half-maximal cytotoxic concentration: > 20000 nM
Compound 4 ended at the assay's limit (the forecaster's own chance of this, stated with the estimate: 85%); the middle value lies beyond the limit too.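

In this assay no new step can be read between compound 3 and compound 4, which both stop at a limit: the limit of > 20000 nM in this assay, at which 4 of the 4 values shown sit. Whether chloro in place of fluoro makes any difference to cytotoxicity stays open, as none of the compounds shown gives a value short of the limit.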